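An Aryl Swap on a Compound Already at the Limit

The source may hold more compounds than are shown below. What is called first, only, known or untested is meant among the compounds shown, and "the series" means these compounds.

Compound 3 `Nc1cccc(-c2cn3nc(-c4cccs4)sc3n2)c1` is the free amine that results when the (1-bromoethenyl)carbonyl group of compound 1 `C=C(Br)C(=O)Nc1cccc(-c2cn3nc(-c4cccs4)sc3n2)c1` is replaced by hydrogen. In a functional assay on L1210 cells (Mus musculus) for inhibition, read by cell counting, with a stated time of 2 days (a lower number here means a stronger inhibitor, a higher number a weaker inhibitor), compound 3 gives only a limit, > 250000 nM, not a measured number. Compound 3 therefore sits at the limit of > 250000 nM in this assay, at which 1 of the 3 values shown sits. Compound 1 gives 170 nM in this assay, and compound 2 `C=C(Br)C(=O)Nc1cccc(-c2cn3nc(Cc4ccccc4)sc3n2)c1` gives 3000 nM. The step of an at least 1400-fold higher number from compound 1 to compound 3 (3.16 log units; beyond the scatter) shows that removing the (1-bromoethenyl)carbonyl group carries the number beyond the range of this assay, whereas the step of an 18-fold higher number from compound 1 to compound 2 (1.25 log units; beyond the scatter) shows that exchanging the group on the aromatic carbon of the shared core moves the number far less.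

Compound 4 `Cc1ccc(-c2nn3cc(-c4cccc(N)c4)nc3s2)cc1` keeps the amine of compound 3 and differs from it only by 4-methylphenyl in place of thiophen-2-yl on an aromatic carbon. Since compound 3 already stands at a limit and the aryl exchange between compound 1 and compound 2 was the smaller of the two measured steps, compound 4 is expected to remain beyond the range of this assay, with an estimated step of a number no higher from compound 3 to compound 4 (the limit leaves the size open). Compound 4 is estimated at 250000 nM, within a range from 100000 nM to 1000000 nM.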

Compound 4, half-maximal inhibitory concentration: 4800 nM
Beside the measured number, compound 4's estimate is 52-fold (1.72 log units) above it; measured number below the stated range.
By their numbers in this assay, from the lowest: compound 1; then compounds 2 and 4 (each within the scatter of the next). At a limit, above all of these: compound 3.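

The position on the aromatic carbon next to the ring nitrogen and the ring sulfur matters in the free amine series too: in this assay, 4-methylphenyl in place of thiophen-2-yl gives an at least 52-fold lower number from compound 3 to compound 4 (1.71 log units; beyond the scatter). Until now this position had been seen to change the number only with the (1-bromoethenyl)carbonyl group on the nitrogen, where benzyl in place of thiophen-2-yl gave an 18-fold higher number from compound 1 to compound 2 (1.25 log units; beyond the scatter), so a free amine on this core can also give a measured number. Compound 3 stands at a limit, so the full size of the new step stays open: the limit of > 250000 nM in this assay, at which 1 of the 4 values shown sits.

The compounds shown leave open whether the methyl group or the six-membered ring carries this change, a question that a plain phenyl would separate. They also leave open what 4-methylphenyl does with the (1-bromoethenyl)carbonyl group on the nitrogen.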